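Adding a Hydroxy Group on the Linker: Two Matched Pairs

The source may hold more compounds than are shown below. What is called first, only, known or untested is meant among the compounds shown, and "the series" means these compounds.

Of the compounds shown here, three have so far been tested in an assay on HEK293 cells for displacement of a labelled ligand from 5-hydroxytryptamine receptor 7 (Homo sapiens), read by scintillation counting, with a stated time of 1 h; a lower number here means a stronger inhibitor, a higher number a weaker inhibitor. Compound 1, `CC(C)c1ccccc1OCCCN1CCC(NS(=O)(=O)c2cccc(F)c2)CC1`, gives 52 nM. Compound 3, `CC(C)c1ccccc1OCC(O)CN1CCC(NS(=O)(=O)c2cccc(F)c2)CC1`, differs from compound 1 by hydroxy in place of hydrogen on a saturated chain carbon bound to two saturated chain carbons, and in this assay compound 3 gives 213 nM; the step of a 4.1-fold higher number from compound 1 to compound 3 (0.61 log units; beyond the scatter) shows that this single change weakened binding. Compound 2, `O=S(=O)(NC1CCN(CCCOc2ccccc2-c2ccccc2)CC1)c1cccc(Cl)c1`, is built on a different core; the difference between its core and that of compound 1 is not broken down here. In this assay compound 2 gives 52 nM, a value level with that of compound 1, so the two cannot be told apart.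

Compound 4, `O=S(=O)(NC1CCN(CC(O)COc2ccccc2-c2ccccc2)CC1)c1cccc(Cl)c1`, has not yet been measured. It relates to compound 2 exactly as compound 3 relates to compound 1: the difference is hydroxy in place of hydrogen on a saturated chain carbon bound to two saturated chain carbons. The change is the same in both pairs and is made at the same kind of place. Because the same change in the pair a 4.1-fold higher number from compound 1 to compound 3 (0.61 log units; beyond the scatter) weakened binding, compound 4 is expected to bind more weakly than compound 2, and the step of a 4.0-fold higher number from compound 2 to compound 4 (0.61 log units; beyond the scatter) is estimated to be of about that size. This expectation rests on a single earlier pair, so the step could turn out somewhat smaller or larger on a different core. For compound 4 the estimated value in this assay is 210 nM, expected to fall between 90 nM and 500 nM.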

Compound 4, inhibition constant: 33 nM
Compound 4: middle estimate off by 6.4-fold (0.80 log units), on the high side; measured number outside the range, below it.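

In this assay, placing hydroxy in place of hydrogen on the saturated chain carbon gives a 1.6-fold lower number from compound 2 to compound 4 (0.20 log units; within the scatter), so compound 4 cannot be told apart from compound 2, whereas the same change clearly weakened binding on the core of compound 1. Set side by side, the two results do not agree, and the gap between them is larger than chance variation between repeated measurements would explain: the same change on two cores in this assay, a 4.1-fold higher number (0.61 log units; beyond the scatter) from compound 1 to compound 3 and a 1.6-fold lower number (0.20 log units; within the scatter) from compound 2 to compound 4, 6.5-fold (0.81 log units) apart, beyond the scatter of two such steps. Among these compounds, this shows that the effect of the hydroxy group on the core of compound 1 cannot simply be carried over to the core of compound 2 in this series, but with only one pair on each core, it does not show which part of the cores accounts for the difference or how the change would behave on any further core.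

The compounds shown leave open whether another group on the same saturated chain carbon, such as an amine or a methoxy group, would also depend on the core. They also leave open how the hydroxy step would run on a core that differs from the core of compound 1 in one place only, which could narrow down the source of the gap.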